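Swapping the aryl group on sulfur in two related benzamides

This account rests on a few compounds, and the source may have more. Where it says the series, first, only, none or still open, it means among the compounds named here.

Of the compounds shown here, three of this set have been tested in a functional assay on SMMC-7721 cells (Homo sapiens) for inhibition, read by CCK-8 assay, with a stated time of 72 h, tested at 8 uM; a higher number here means more inhibition of growth at the concentration tested, a lower number less inhibition of growth. Compound 1 `Cc1cc(C)cc(SCc2ccc(/C=C/C(=O)Nc3ccccc3N)cc2)c1` gives 7.13%. Compound 2 `Nc1ccccc1NC(=O)/C=C/c1ccc(CSc2ccc(Cl)cc2)cc1` gives 16.5% in this assay. Compound 3 `Nc1ccccc1NC(=O)c1ccc(CSc2ccc(Cl)cc2)cc1` gives 16.5% in this assay, level with compound 2 at the digits shown, while the gap to compound 1 lies within the scatter. The difference between the core of compound 2 and the core of compound 3 is not broken down here. Compound 1 arises from compound 2 by one change, (3,5-dimethylphenyl in place of 4-chlorophenyl on a sulfur), and that step reads a number 9.4 percentage points lower from compound 2 to compound 1 (within the scatter). The unmeasured compound 4 `Cc1cc(C)cc(SCc2ccc(C(=O)Nc3ccccc3N)cc2)c1` arises from compound 3 by the same change, (3,5-dimethylphenyl in place of 4-chlorophenyl on a sulfur), at a place described in the same words. Among the compounds with values here, for compound 4 the step from compound 3 is expected to be a number 7.5 percentage points lower from compound 3 to compound 4 (within the scatter), which rests on the single earlier step between compound 2 and compound 1 and on the fact that that step lay within the scatter. Compound 4 is therefore expected to give 9% in this assay, with a range from 0% to 20%.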

Compound 4, percent growth inhibition at one concentration: 85.1%
Compound 4: the middle estimate sits 76.1 percentage points below what was measured, outside the stated range (above it).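

On the core of compound 3, 3,5-dimethylphenyl in place of 4-chlorophenyl on a sulfur reads in this assay as a number 68.6 percentage points higher from compound 3 to compound 4 (beyond the scatter). The same change therefore does not carry from one core to the other at one size: the same change on two cores in this assay, a number 9.4 percentage points lower (within the scatter) from compound 2 to compound 1 and a number 68.6 percentage points higher (beyond the scatter) from compound 3 to compound 4, 78 percentage points apart, beyond the scatter of two such steps This shows that, for these two pairs, the outcome of the change depends on the core that carries it, but with a single pair on each core it does not show why the two cores part or how the change would read on any further core.

The compounds shown carry only these two aryl groups on the sulfur, so they leave open whether the high reading of compound 4 is tied to 3,5-dimethylphenyl itself or would also appear with a plain phenyl, a single methyl or a methoxy group on that ring. They also leave open what a longer chain in place of the saturated chain carbon on the sulfur would do on the core of compound 4.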